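A terminal hydroxyl on the side chain of a vitamin D3 receptor ligand

This account rests on a few compounds, and the source may have more. Where it says the series, first, only, none or still open, it means among the compounds named here.

Of the compounds shown here, three have been tested in an assay on HEK293 cells for agonist activity at vitamin D3 receptor (Homo sapiens), read by a beta-galactosidase reporter; a lower number here means that less compound is needed, a higher number that more compound is needed for the effect. Compound 1, `CCC(CC)(c1ccc(OC[C@@H](O)CO)c(C)c1)c1ccc(OC[C@H](O)C(C)(C)OCCCCCCCCO)c(C)c1`, gives 1200 nM. Compound 2, `CCCCCCCCCCOC(C)(C)[C@@H](O)COc1ccc(C(CC)(CC)c2ccc(OC[C@@H](O)CO)c(C)c2)cc1C`, is reported as "not active" (no number reported). Compound 3, `CCCCCCOC(C)(C)[C@H](O)COc1ccc(C(CC)(CC)c2ccc(OC[C@@H](O)CO)c(C)c2)cc1C`, returns only a limit of the assay, > 10000 nM, so it sits at the limit of > 10000 nM in this assay, at which 1 of the 3 values shown sits, and no single number is known for it.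

Compound 4, `CCC(CC)(c1ccc(OC[C@@H](O)CO)c(C)c1)c1ccc(OC[C@@H](O)C(C)(C)OCCCCCCCCO)c(C)c1`, is not yet measured. It differs from compound 3 by 2-hydroxyethyl in place of hydrogen on a saturated chain carbon, six bonds along the chain from an oxygen on a saturated carbon. Going by the values given here, no step between two measured compounds is known that isolates this change, so no measured step can be used as a guide; the only measured compound carrying the 2-hydroxyethyl-extended chain is compound 1 with its 1200 nM.

Compound 4 is therefore expected to move in the direction of lower values, with the step from compound 3 to compound 4 estimated as an at least 12-fold lower number from compound 3 to compound 4 (1.09 log units; beyond the scatter). The estimate for compound 4 in this assay is 800 nM, with a range from 150 nM to 5000 nM.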

Compound 4, half-maximal effective concentration: > 3000 nM
Compound 4: only a limit was reported (the forecaster's own chance of this, stated with the estimate: 20%); middle value at least 3.7-fold (0.57 log units) away from the limit.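

The position carrying the 2-hydroxyethyl extension now has a partner that separates the chain from its configuration. In this assay there is an at least 2.5-fold higher number from compound 1 to compound 4 (0.39 log units; beyond the scatter), so the hydroxyl-ended chain does not by itself secure the value of compound 1, and the way the chain carbon is drawn counts as well. That gap can be assigned to configuration alone: the fact that compounds 1 and 4 differ only in the configuration as drawn.

From the compounds shown here alone, compound 4 gives only a limit of the assay, > 3000 nM, and compound 3 also gives only a limit, so the step between them cannot be read and the effect of adding the 2-hydroxyethyl extension stays unknown. The compounds shown also leave open whether a carboxylic acid or an amine at the chain end, in place of the hydroxyl, would keep a measurable value in either configuration.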